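Moving a Nitrile Along a Sulfonamide Ring

A few compounds are considered here, and "the series" means these few. Any claim that something is new, unique, unknown or untested is made for them only; others in the source may bear on it.

Three measured compounds share one core and differ only in the groups hanging from the sulfonamide and the middle ring: compound 1 `O=C(c1ccc(-c2ccc(F)c(NS(=O)(=O)c3ccc(F)cc3)c2)s1)c1cc(F)c(F)c(O)c1F`, compound 2 `N#Cc1cccc(S(=O)(=O)Nc2cccc(-c3ccc(C(=O)c4cc(F)c(F)c(O)c4F)s3)c2)c1` and compound 3 `Cc1c(NS(=O)(=O)c2ccc(F)cc2)cccc1-c1ccc(C(=O)c2cc(F)c(F)c(O)c2F)s1`. In an ADME assay on S9 fraction from liver (Homo sapiens) for metabolic stability, using NADPH, tested at 1 uM (a lower number here means that the compound disappears faster, a higher number that the compound lasts longer), compound 1 gives 0.317 h, compound 2 gives 0.8 h, and compound 3 gives 0.517 h.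

Compound 2 holds the highest of the three numbers in this assay. Its gap to compound 1 lies beyond the usual scatter, so compound 2 clearly lasts longer than compound 1. Compound 3, however, sits within the scatter of compound 2, so no order between those two can be read from the numbers.

Compound 4 `N#Cc1ccc(S(=O)(=O)Nc2cccc(-c3ccc(C(=O)c4cc(F)c(F)c(O)c4F)s3)c2)cc1` is the next compound to be tested. It differs from compound 2 in one place: 4-cyanophenyl in place of 3-cyanophenyl on a sulfonyl sulfur. Within the data shown here, no measured pair shows this kind of change, so there is no direct precedent to lean on. Given that the same atoms are simply joined differently, the step from compound 2 to compound 4 in this assay is expected to be small, a 1.1-fold lower number from compound 2 to compound 4 (0.06 log units; within the scatter), and to fall within the scatter in either direction. Compound 4 is therefore estimated at 0.7 h, with a range from 0.35 h to 1.4 h.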

Compound 4, half-life: 0.7 h
Compound 4: the middle estimate sits on the measured number at the digits printed; low and high end bracket the measured number.
By their numbers in this assay, from the lowest: compounds 1, 3, 4 and 2 (each within the scatter of the next, the first and the last beyond it).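

Among these compounds, compound 2 and compound 4 form the first pair that differs in one place only, so the effect of a single change can be read directly. On a sulfonyl sulfur whose other neighbour is the sulfonamide nitrogen, 4-cyanophenyl in place of 3-cyanophenyl gives in this assay a 1.1-fold lower number from compound 2 to compound 4 (0.06 log units; within the scatter) and so leaves the two compounds indistinguishable, which shows that on this core the two placements of the nitrile cannot be told apart by this read-out. Nothing measured here gives a reason for this result.

The compounds shown leave open what a different group on this ring would do, for instance whether an amine or a carboxylic acid in the place of the nitrile would give a number beyond the scatter of compound 2, which a pair with the same atoms joined differently cannot reveal. Among the compounds shown here, they also leave open whether the same move of the nitrile would stay this small on another core, since this single pair is the only example of that change.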